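Truncating the piperidine carbamate to a trifluoroacetyl group

This account rests on a few compounds, and the source may have more. Where it says the series, first, only, none or still open, it means among the compounds named here.

Compound 1 `Cc1nc(S(C)(=O)=O)ccc1Oc1ncnc(OC2CCN(C(=O)O[C@@H](C)CF)CC2)c1F`: 186 nM
Compound 2 `Cc1nc(S(C)(=O)=O)ccc1Oc1ncnc(OC2CCN(C(=O)O[C@@H](C)C(F)(F)F)CC2)c1F`: 9.86 nM

Among the compounds with values here, in a functional assay on isolated protein for inhibition of Glucose-dependent insulinotropic receptor (Homo sapiens), read by HTRF and cAMP accumulation (a lower number here means that less compound is needed, a higher number that more compound is needed for the effect), compound 1 gives 186 nM, the higher of the two numbers measured so far; compound 2 gives 9.86 nM. Within the data shown here, the single measured step, a 19-fold lower number from compound 1 to compound 2 (1.28 log units; beyond the scatter), keeps the carbamate intact and alters only the end of the chain. Compound 3 `Cc1nc(S(C)(=O)=O)ccc1Oc1ncnc(OC2CCN(C(=O)C(F)(F)F)CC2)c1F` arises from compound 1 by a group of 4 heavy atoms (1 carbon, 3 fluorine; no ring) in place of a group of 5 heavy atoms (3 carbon, 1 oxygen, 1 fluorine; no ring), on a carbonyl carbon. The measured step bears only loosely on this change, as the carbamate oxygen and its chain are lost altogether rather than modified. A moderate rise in the number is expected, a 2.4-fold higher number from compound 1 to compound 3 (0.38 log units; beyond the scatter). Compound 3 is estimated at 450 nM, within 80 nM to 2500 nM.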

Compound 3, half-maximal effective concentration: 151 nM
Compound 3: middle estimate off by 3.0-fold (0.47 log units), on the high side, and the stated range covers the measured number.
By their numbers in this assay, from the lowest: compound 2; then compounds 3 and 1 (each within the scatter of the next).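

In this assay, trifluoromethyl on the carbonyl carbon replaces the group of 5 heavy atoms with a 1.2-fold lower number from compound 1 to compound 3 (0.09 log units; within the scatter), so these two end groups cannot be told apart here. Set against 1-(trifluoromethyl)ethoxy, the same trifluoromethyl gives a 15-fold higher number from compound 2 to compound 3 (1.19 log units; beyond the scatter), so trifluoromethyl directly on the carbonyl carbon does not keep the low number of compound 2. No available evidence explains either step.

Still open, from the compounds shown here alone, is whether an amine or a longer chain on that carbonyl carbon could match compound 2. Going by these compounds, the effect of the opposite stereocentre in 1-(trifluoromethyl)ethoxy also remains open.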